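A few compounds are considered here, and "the series" means these few. Any claim that something is new, unique, unknown or untested is made for them only; others in the source may bear on it.

Values in a functional assay on A549 cells (Homo sapiens) for cytotoxicity, read by MTT assay, with a stated time of 72 h; a higher number here means a weaker inhibitor, a lower number a stronger inhibitor:
- compound 1 `Cc1ccc(C(=O)Nc2nnc(-c3ccc(O)c(O)c3)s2)cc1`: 11800 nM
- compound 2 `O=C(Nc1nnc(-c2cccc(O)c2O)s1)c1ccccc1`: 12300 nM
- compound 3 `Cc1ccc(C(=O)Nc2nnc(-c3cccc(O)c3O)s2)cc1`: 11300 nM

Compound 1 stands within the scatter of both compound 2 and compound 3, so the three values show no order.

Not yet measured is compound 4 `O=C(Nc1nnc(-c2ccc(O)c(O)c2)s1)c1ccccc1`, which differs from compound 1 as follows: hydrogen in place of methyl on an aromatic carbon. In words, this is hydrogen in place of methyl on an aromatic carbon.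

Going by the values given here, one measured step bears on this change. It is the same exchange run the opposite way, methyl in place of hydrogen on an aromatic carbon, in a pair whose core differs from that of compound 1: a 1.1-fold lower number from compound 2 to compound 3 (0.04 log units; within the scatter). Among the compounds with values here, with only this single step as a guide, no step beyond the scatter is expected in this assay, and no direction can be assigned.

The expected step is a 1.0-fold higher number from compound 1 to compound 4 (0.01 log units; within the scatter). For compound 4 the estimated value is 12000 nM, with an expected range from 7000 nM to 20000 nM.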

Compound 4, half-maximal inhibitory concentration: 13000 nM
Beside the measured number, compound 4's estimate is 1.1-fold (0.03 log units) below it, and the stated range covers the measured number.
By their numbers in this assay, from the lowest: compounds 3, 1, 2 and 4 (each within the scatter of the next).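

In this assay, the change from 4-methylphenyl to phenyl gives a 1.1-fold higher number from compound 1 to compound 4 (0.04 log units; within the scatter), so the core of compound 1 now has its own reading for this exchange and no longer depends on a step taken from another core. The exchange reads alike on both cores: the same change on two cores in this assay, a 1.1-fold lower number (0.04 log units; within the scatter) from compound 2 to compound 3 and a 1.1-fold lower number (0.04 log units; within the scatter) from compound 4 to compound 1, 1.0-fold (0.01 log units) apart, within the scatter of two such steps Neither pair separates from the scatter, so methyl and hydrogen cannot be told apart at this position, para to a large group, on either core.

Only hydrogen and methyl are shown at this position, so it remains open whether a methoxy group, an amine, a carboxylic acid or a longer chain there would give a step beyond the scatter. Going by these compounds, whether the flat reading between methyl and hydrogen carries over to any other assay also remains open.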